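This account rests on a few compounds, and the source may have more. Where it says the series, first, only, none or still open, it means among the compounds named here.

The measured compounds: compound 1 `COc1ccc(/C=C\c2cc(OC)c(OC)c(OC)c2)cc1OCc1ccc(CN2CCCC[C@H]2C(=O)O)cc1`, compound 2 `COc1ccc(/C=C\c2cc(OC)c(OC)c(OC)c2)cc1OCc1ccc(CN2CCCCC2C(=O)O)cc1`, compound 3 `COc1ccc(/C=C\c2cc(OC)c(OC)c(OC)c2)cc1OCc1ccc(CN2CC[C@@H](C(=O)O)C2)cc1`.

In a functional assay on MC-38 cells (Mus musculus) for antiproliferative activity, read by CCK-8 assay, with a stated time of 48 h (a lower number here means a stronger inhibitor, a higher number a weaker inhibitor), compound 1 gives only a limit, > 10000 nM. Compound 2 gives 5400 nM and compound 3 gives 6300 nM in this assay. Compound 1 thus stands at the weak end, resting on (the limit of > 10000 nM in this assay, at which 1 of the 3 values shown sits). The step to compound 4 `COc1ccc(/C=C\c2cc(OC)c(OC)c(OC)c2)cc1OCc1ccc(CN2CCCC[C@@H]2C(=O)O)cc1` is the two compounds have the same atoms and bonds and differ only in configuration as drawn: 1 of 2 stereo elements differ; a stereocentre at a saturated ring carbon is drawn S in compound 1 and R in compound 4. The step of an at least 1.8-fold lower number from compound 1 to compound 2 (0.26 log units; that floor lies within the scatter) bears on it, since it rests on (the fact that one of compounds 1 and 2 is drawn with a defined configuration and the other without, at the place where they differ); the step of an at least 1.5-fold lower number from compound 1 to compound 3 (0.20 log units; that floor lies within the scatter) changes the ring and is less telling. Compound 4 is expected to fall on the stronger side of compound 2 in this assay, with the step of an at least 2.8-fold lower number from compound 1 to compound 4 (0.45 log units; beyond the scatter) expected. Compound 4 is estimated at 3500 nM, between 1500 nM and 8000 nM.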

Compound 4, half-maximal inhibitory concentration: > 10000 nM
Compound 4: only a limit was reported; the forecaster's own chance of this, stated with the estimate: 10%; middle value at least 2.8-fold (0.45 log units) from the limit.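

In this assay compound 4 gives > 10000 nM, which is a limit, and compound 1 also sits at a limit, so the R and S drawings at this ring carbon cannot be told apart and the step between them cannot be read: the fact that compounds 1 and 4 differ only in the configuration as drawn. The record holds an at least 1.8-fold higher number from compound 2 to compound 4 (0.26 log units; that floor lies within the scatter) and an at least 1.5-fold higher number from compound 3 to compound 4 (0.20 log units; that floor lies within the scatter), so neither floor sets compound 4 apart from the other compound: the fact that one of compounds 2 and 4 is drawn with a defined configuration and the other without, at the place where they differ.

Left open are the true values of compound 1 and compound 4. Also open, as far as these compounds go, is whether a methyl ester in place of the carboxylic acid of the 2-carboxypiperidin-1-yl group would give a value inside the range of this assay.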